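This account rests on a few compounds, and the source may have more. Where it says the series, first, only, none or still open, it means among the compounds named here.

Compound 1 `CS(=O)(=O)c1cnc(O[C@H]2CC[C@H](OC3CCN(C(=O)OC4CCOC4)CC3)CC2)cn1` gives 427 nM in a functional assay on isolated protein for agonist activity at Glucose-dependent insulinotropic receptor (Homo sapiens), read by HTRF and cAMP accumulation; a lower number here means that less compound is needed, a higher number that more compound is needed for the effect. Compound 2 `CS(=O)(=O)c1cnc(O[C@H]2CC[C@H](OC3CCN(C(=O)C4(C(F)(F)F)CCCC4)CC3)CC2)cn1` gives 38.4 nM in this assay, and an 11-fold lower number from compound 1 to compound 2 (1.05 log units; beyond the scatter), so compound 2 holds the lowest of the two numbers. Compound 3 `CS(=O)(=O)c1cnc(O[C@H]2CC[C@H](OC3CCN(C(=O)C4(C(F)(F)F)CC4)CC3)CC2)cn1` carries a group of 7 heavy atoms (4 carbon, 3 fluorine; one three-membered non-aromatic ring of carbon only) in place of a group of 9 heavy atoms (6 carbon, 3 fluorine; one five-membered non-aromatic ring of carbon only), on a carbonyl carbon. Within the data shown here, the single measured step exchanged a ring with one hetero atom for the trifluoromethyl-bearing ring; no measured step contracts that ring while keeping the trifluoromethyl, so the earlier step bears on this change only loosely. A small shift or none beyond the scatter is expected. For compound 3 the estimate is 55 nM, with a range from 20 nM to 160 nM. The expected step is a 1.4-fold higher number from compound 2 to compound 3 (0.16 log units; within the scatter).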

Compound 3, half-maximal effective concentration: 107 nM
The estimate for compound 3 lay 1.9-fold (0.29 log units) below the measured number; low and high end bracket the measured number.
By their numbers in this assay, from the lowest: compound 2; then compound 3; then compound 1.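

At this carbonyl carbon, ring size alone moves the number in this assay, with a 2.8-fold higher number from compound 2 to compound 3 (0.45 log units; beyond the scatter), so the five-membered carbon ring and the three-membered one are not interchangeable when trifluoromethyl is kept. The smaller ring still retains part of the gain over (oxolan-3-yl)oxy, with a 4.0-fold lower number from compound 1 to compound 3 (0.60 log units; beyond the scatter) and the five-membered ring giving the lowest number of the three. Nothing available accounts for this dependence on ring size. Open, as far as these compounds go, is how a four-membered or six-membered carbon ring would read here. Also open, from the compounds shown here alone, is whether methyl or nitrile could replace trifluoromethyl on the ring.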